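A few compounds are considered here, and "the series" means these few. Any claim that something is new, unique, unknown or untested is made for them only; others in the source may bear on it.

Measured so far:
compound 1 `O=C(O)c1cn(Cc2ccc(O)cc2)c2ccccc2c1=O` gives 62.7% in a functional assay, tested at 100 uM; a lower number here means a weaker effect, a higher number a stronger effect of the compound at the concentration tested;
compound 2 `O=C(NO)c1cn(Cc2ccc(Cl)cc2)c2ccccc2c1=O` gives 31.7% in this assay;
compound 3 `O=C(NO)c1cn(Cc2ccc(Br)cc2)c2ccccc2c1=O` gives 27.6% in this assay.

In this assay compound 3 stands lowest of the three numbers; its gap to compound 2 is within the scatter, its gap to compound 1 is beyond it. Within the data shown here, the only measured step that changes one place is a number 4.1 percentage points lower from compound 2 to compound 3 (within the scatter), so swapping one halogen for another on this aromatic carbon left the read-out essentially unchanged.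

Compound 4 `O=C(NO)c1cn(Cc2ccc(O)cc2)c2ccccc2c1=O` is not yet measured. It differs from compound 3 by hydroxy in place of bromo on an aromatic carbon. Among the measured compounds shown here, no measured step covers a halogen giving way to hydroxy, and no step covers the difference between compound 1 and compound 4, so those two values can only be set side by side: compound 1 carries the same hydroxy group and sits well above compound 3. Only the halogen-to-halogen step bears directly here, and it was flat. For compound 4 a moderate rise is expected, a number 10.4 percentage points higher from compound 3 to compound 4 (beyond the scatter), with wide uncertainty. The estimate for compound 4 is 38%, range 18% to 62%.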

Compound 4, a percentage reported as activity, at one concentration (the size of the read-out at that concentration, not a potency): 74.9%
Compound 4: middle estimate off by 36.9 percentage points, on the low side; the whole stated range lies below it.
By their numbers in this assay, from the lowest: compounds 3 and 2 (each within the scatter of the next); then compound 1; then compound 4.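

In this assay, this para position on the aromatic ring proves sensitive to the kind of group it carries: 4-bromophenyl to 4-hydroxyphenyl gives a number 47.3 percentage points higher from compound 3 to compound 4 (beyond the scatter) and hydroxy in place of chloro gives a number 43.2 percentage points higher from compound 2 to compound 4 (beyond the scatter), whereas the halogen swap alone had stayed flat. With hydroxy held in place, hydroxyamino in place of hydroxy on the carbonyl carbon gives a number 12.2 percentage points higher from compound 1 to compound 4 (beyond the scatter), a modest step and smaller than either step at the aromatic carbon. Nothing available explains why hydroxy and the halogens differ so much.

As far as these compounds go, whether this rise is specific to hydroxy stays open, since an amine, a methoxy group or a carboxylic acid at the same place would test it. Each read-out comes from a single concentration, so it speaks only of a stronger or weaker effect at that concentration.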